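A few compounds are considered here, and "the series" means these few. Any claim that something is new, unique, unknown or untested is made for them only; others in the source may bear on it.

In a functional assay on cells for antagonist activity at C-C chemokine receptor type 4 (Homo sapiens), read by GTPgammaS binding (a higher number here means a weaker inhibitor, a lower number a stronger inhibitor), compound 1 `COc1nn(C)c2ncnc(NS(=O)(=O)c3cccc(Cl)c3Cl)c12` gives 63.1 nM, compound 2 `CNC(=O)Cn1nc(OC)c2c(NS(=O)(=O)c3cccc(Cl)c3Cl)ncnc21` gives 631 nM, and compound 3 `COc1nn(C2COC2)c2ncnc(NS(=O)(=O)c3cccc(Cl)c3Cl)c12` gives 251 nM, the second highest of the three numbers. The measured steps that touch the same aromatic nitrogen are a 4.0-fold higher number from compound 1 to compound 3 (0.60 log units; beyond the scatter) and a 2.5-fold lower number from compound 2 to compound 3 (0.40 log units; beyond the scatter), both modest and pointing in opposite directions. Compound 4 `COc1nn(CCN(C)C)c2ncnc(NS(=O)(=O)c3cccc(Cl)c3Cl)c12` carries 2-(dimethylamino)ethyl in place of oxetan-3-yl on an aromatic nitrogen. Going by the values given here, no measured compound bears this chain, so the direction of the change cannot be read from the earlier steps; their size suggests a modest shift at most. Compound 4 is therefore expected to show a 1.3-fold lower number from compound 3 to compound 4 (0.10 log units; within the scatter), a step of modest size. In this assay compound 4 is estimated at 200 nM, with a range from 60 nM to 700 nM.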

Compound 4, half-maximal inhibitory concentration in the C-C chemokine receptor type 4 assay: 3980 nM
Estimate against measurement, compound 4: 20-fold (1.30 log units) below; the measured number lies above the stated range.
By their numbers in the C-C chemokine receptor type 4 assay, from the lowest: compound 1; then compound 3; then compound 2; then compound 4.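

On this aromatic nitrogen, 2-(dimethylamino)ethyl gives the weakest inhibitor of the four in the C-C chemokine receptor type 4 assay, with a 16-fold higher number from compound 3 to compound 4 (1.20 log units; beyond the scatter), a 6.3-fold higher number from compound 2 to compound 4 (0.80 log units; beyond the scatter) and a 63-fold higher number from compound 1 to compound 4 (1.80 log units; beyond the scatter). The position therefore allows far larger shifts than the earlier substituents showed. The same change from oxetan-3-yl also gives the more soluble compound in a physicochemical assay for solubility, read by chemiluminescence, measured as kinetic solubility; a lower number here means a less soluble compound, a higher number a more soluble compound (compound 3 gives 142000 nM and compound 4 gives 358000 nM): the measured solubility of compound 3, 142000 nM, and of compound 4, 358000 nM, a 2.5-fold higher number (0.40 log units; beyond the scatter)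

As far as these compounds go, whether the higher number in the C-C chemokine receptor type 4 assay follows from the dimethylamino group or from the ethyl chain stays open. A 2-methoxyethyl group or a 3-(dimethylamino)propyl chain on this nitrogen would help separate the two.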